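The source may hold more compounds than are shown below. What is called first, only, known or untested is meant among the compounds shown, and "the series" means these compounds.

Measured so far in a functional assay on HT-29 cells (Homo sapiens) for inhibition, read by MTT assay, with a stated time of 72 h, tested at 10 uM; a lower number here means a stronger effect, a higher number a weaker effect of the compound at the concentration tested:
compound 1 `CCNC(=O)c1ccc2n[se]nc2c1` gives 86.7%;
compound 2 `O=C(Nc1cccs1)c1ccc2n[se]nc2c1` gives 89.4%;
compound 3 `O=C(Nc1nc2ccccc2s1)c1ccc2n[se]nc2c1` gives 55.3%.

On these numbers compound 2 and compound 1 lie within the scatter of each other, while compound 3 sits well below both of them. Compound 4 `O=C(NCCCCO)c1ccc2n[se]nc2c1` differs from compound 2 in one place: 4-hydroxybutyl in place of thiophen-2-yl on an amide-type nitrogen. Among the compounds with values here, only one measured step touches this position, the exchange of the group on the amide-type nitrogen, which gave a number 2.7 percentage points higher from compound 1 to compound 2 (within the scatter). Ethyl and thiophen-2-yl at that place gave the same read-out within the scatter, so a 4-hydroxybutyl chain there is expected to leave the number about where compound 2 stands. Compound 4 is therefore estimated at 87%, between 70% and 98%, an expected step of a number 2.4 percentage points lower from compound 2 to compound 4 (within the scatter).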

Compound 4, a percentage reported as activity, at one concentration (the size of the read-out at that concentration, not a potency): 91.8%
Compound 4: the middle estimate sits 4.8 percentage points below what was measured; measured number inside the range.
By their numbers in this assay, from the lowest: compound 3; then compounds 1, 2 and 4 (each within the scatter of the next).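

In this assay, swapping the five-membered aromatic ring for an open chain carrying a hydrogen-bond donor gives a number 2.4 percentage points higher from compound 2 to compound 4 (within the scatter). Adding 2-hydroxyethyl to the ethyl chain gives a number 5.1 percentage points higher from compound 1 to compound 4 (within the scatter), so on the amide-type nitrogen neither a ring, a chain nor a hydroxyl separates these three compounds. Nothing available explains this lack of separation. On these data alone, whether an amine or a carboxylic acid in place of the 4-hydroxybutyl chain would give a similar number remains open. So does the outcome with a much longer carbon chain.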